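The compounds below may be only part of what the source reports. "The series", "measured", "known", "first", "only" and "open" are said of these compounds alone.

Measured in a functional assay on MDA-MB-435 cells (Homo sapiens) for cytotoxicity, read by MTT assay, with a stated time of 72 h; a lower number here means a stronger inhibitor, a higher number a weaker inhibitor:
Compound 1 `Nc1ccc(Nc2c(C(=O)NCc3ccc(F)cc3)nc(Br)c3cccnc23)cc1`: 7000 nM
Compound 2 `N[C@H]1CC[C@H](Nc2c(C(=O)NCc3ccccn3)nc(Br)c3cccnc23)CC1`: 4000 nM
Compound 3 `COC(=O)c1nc(Br)c2cccnc2c1N[C@H]1CC[C@H](N)CC1`: > 20000 nM

The value of compound 3 is a limit of this assay, not a number (the limit of > 20000 nM in this assay, at which 1 of the 3 values shown sits). Of the two numbers, compound 1 gives the higher; its nearest neighbour is compound 2, whose value lies within the scatter of it, so no order between the two is claimed.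

Within the data shown here, the only measured step, an at least 5.0-fold higher number from compound 2 to compound 3 (0.69 log units; beyond the scatter), changes the carbonyl substituent. Among the measured compounds shown here, the change to compound 4 `NCCCCCCNc1c(C(=O)NCc2ccc(F)cc2)nc(Br)c2cccnc12` is 6-aminohexyl in place of 4-aminophenyl on a nitrogen on an aromatic ring, on the nitrogen on the aromatic ring, where no measured step exists. Nothing shown therefore bears on it, and a step of no more than the scatter in either direction is expected, no change at the digits printed from compound 1 to compound 4 (within the scatter). Compound 4 is estimated at 7000 nM, between 2500 nM and 20000 nM.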

Compound 4, half-maximal inhibitory concentration: 6000 nM
The estimate for compound 4 lay 1.2-fold (0.07 log units) above the measured number, and the stated range covers the measured number.
By their numbers in this assay, from the lowest: compounds 2, 4 and 1 (each within the scatter of the next). At a limit, above all of these: compound 3.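

In this assay, replacing 4-aminophenyl with 6-aminohexyl on the nitrogen on the aromatic ring gives a 1.2-fold lower number from compound 1 to compound 4 (0.07 log units; within the scatter). Among these compounds, this is the first step read at this position, and it shows that an aromatic ring in this group is not required to stay in this range of values: the chain without a ring reads the same within the scatter. No measured property bears on this step.

Open, going by these compounds, is whether a shorter chain on this nitrogen reads alike. Also open, on these data alone, is whether a carboxylic acid in place of the terminal amine does.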